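Replacing piperidine with methoxyazetidine on the amide

A few compounds are considered here, and "the series" means these few. Any claim that something is new, unique, unknown or untested is made for them only; others in the source may bear on it.

Going by the values given here, compound 1 `O=C(Nc1sc2c(c1C(=O)N1CCCCC1)CCOC2)c1ccccc1C(F)(F)F` is one of two compounds measured in an in vitro ADME assay on microsomes from liver (Rattus norvegicus) for metabolic stability; on this read-out higher numbers stand for a longer-lived compound and lower numbers for a shorter-lived compound; compound 1 gives 0.088 h. Compound 2 `O=C(Nc1sc2c(c1C(=O)N1CCCCC1)CCOC2)c1ccccc1OC(F)(F)F` gives 0.0587 h in this assay, and the step of a 1.5-fold lower number from compound 1 to compound 2 (0.18 log units; within the scatter) changes only the aromatic substituent. Compound 3 `COC1CN(C(=O)c2c(NC(=O)c3ccccc3C(F)(F)F)sc3c2CCOC3)C1` differs from compound 1 elsewhere: 3-methoxyazetidin-1-yl in place of piperidin-1-yl on a carbonyl carbon. No measured step touches the amide ring, so nothing shown bears directly on this change, and the expectation is a step of no clear direction within the scatter. Compound 3 is therefore expected to give 0.1 h in this assay, between 0.04 h and 0.25 h, a step of a 1.1-fold higher number from compound 1 to compound 3 (0.06 log units; within the scatter).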

Compound 3, half-life: 0.84 h
For compound 3 the middle estimate is 8.4-fold (0.92 log units) below the measured one; measured number outside the range, above it.
By their numbers in this assay, from the lowest: compounds 2 and 1 (each within the scatter of the next); then compound 3.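

Going by these compounds alone, the amide ring, which no earlier step touched, proves to be a place where this assay responds strongly (a 9.5-fold higher number from compound 1 to compound 3 (0.98 log units; beyond the scatter)). The entering and leaving groups have the same count of heavy atoms, yet the ring shrinks from six-membered to four-membered and a hydrogen-bond acceptor enters, and this single step cannot separate those two differences. Nothing shown accounts for the step.

The compounds shown leave open whether the ring or the methoxy group carries the step, a question that plain azetidin-1-yl or morpholin-4-yl on the same carbonyl carbon would address. Going by these compounds, whether the step holds with trifluoromethoxy in place of trifluoromethyl also remains open.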